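The source may report more compounds than this note shows. Statements on the series, on what has been measured and on what is new or still open speak of the compounds shown alone.

Compound 3, whose structure is `CCCSc1nc(N)nc2c1ncn2/C=C1/CC1(CO)CO`, belongs to a small set in which the same core carries different groups on one aromatic carbon. In an ADME assay on HFF cells (Homo sapiens) for cytotoxicity, with a stated time of 8 days (a higher number here means that more compound is tolerated, a lower number that less compound is tolerated), compound 3 gives > 300000 nM, which is a limit of the assay and not a number. Compound 1, with the structure `CCCOc1nc(N)nc2c1ncn2/C=C1/CC1(CO)CO`, gives > 300000 nM in this assay, again a limit. Compound 2, with the structure `CCCCNc1nc(N)nc2c1ncn2/C=C1/CC1(CO)CO`, gives > 300000 nM in this assay, also a limit. Because all three sit at the limit of > 300000 nM in this assay, at which 3 of the 3 values shown sit, the steps between them cannot be read: the step that the two limits leave unreadable from compound 1 to compound 2, the step that the two limits leave unreadable from compound 1 to compound 3 and the step that the two limits leave unreadable from compound 2 to compound 3 are each left unreadable by the two limits. Compound 4, whose structure is `Nc1nc(NC2CCCC2)c2ncn(/C=C3/CC3(CO)CO)c2n1`, has not yet been measured. It differs from compound 3 in one place: cyclopentylamino in place of propylsulfanyl on an aromatic carbon. For the measured compounds named here, none of the measured steps gives a readable size for such a change, and all three measured compounds sit at the same limit, so no direction beyond the scatter can be drawn from them. Compound 4 is therefore expected to sit at the same limit, with an estimated value of 300000 nM in this assay, within the range 100000 nM to 300000 nM. The step this estimate means is a number no higher from compound 3 to compound 4 (the limit leaves the size open), expected to be none beyond the scatter.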

Compound 4, half-maximal cytotoxic concentration: > 300000 nM
Compound 4: only a limit was reported; the forecaster's own chance of this, stated with the estimate: 85%; the middle value sits exactly at the limit.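

No new step can be read from compound 1, compound 2 or compound 3 to compound 4, because all four stand at a limit of the assay and not at a number: the limit of > 300000 nM in this assay, at which 4 of the 4 values shown sit.

The compounds shown leave open where the half-maximal cytotoxic concentration of each actually lies in this assay, and whether the group on this aromatic carbon changes it.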